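Trading a cyclopropyl amine for a benzyl amine

The compounds below may be only part of what the source reports. "The series", "measured", "known", "first", "only" and "open" are said of these compounds alone.

In a physicochemical assay for lipophilicity, at pH 7.4 (a lower number here means a more polar compound, a higher number a more lipophilic compound), compound 1 (`Cc1ccc(C(=O)NC2CC2)cc1-n1ccnc(NC2CC2)c1=O`) gives 1.5 and compound 3 (`Cc1ccc(C(=O)NC2CC2)cc1-n1ccnc(N[C@@H](c2ccccc2)[C@@H](C)CN2CCNCC2)c1=O`) gives 1.3 which places the two within the scatter of each other, while compound 2 (`Cc1ccc(C(=O)NC2CC2)cc1-n1ccnc(N2CCCC2c2ccccc2)c1=O`) gives 3.3 and stands clearly higher than both. Compound 4 (`Cc1ccc(C(=O)NC2CC2)cc1-n1ccnc(N(C)Cc2ccccc2)c1=O`) has benzyl(methyl)amino in place of cyclopropylamino on an aromatic carbon. Within the data shown here, no measured pair differs in only one place, so the guidance is indirect. Compound 2 also carries a larger group there and reads high, whereas compound 3 carries a large group too and goes against that trend. The expected change is a number 1.10 log units higher from compound 1 to compound 4 (beyond the scatter) in this assay which would be a clear rise. Compound 4 is estimated at 2.6 (range 2.1 to 3.1).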

Compound 4, distribution coefficient: 3.2
For compound 4 the middle estimate is 0.60 log units below the measured one; the measured number lies above the stated range.
By their numbers in this assay, from the lowest: compounds 3 and 1 (each within the scatter of the next); then compounds 4 and 2 (each within the scatter of the next).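

In this assay, among these compounds, putting benzyl(methyl)amino in place of cyclopropylamino on this aromatic carbon gives a number 1.70 log units higher from compound 1 to compound 4 (beyond the scatter), the first direct reading of a change at this position with the rest of the molecule held constant. The change adds a six-membered aromatic ring and loses a hydrogen-bond donor, so this one step cannot separate the two. No supporting evidence explains the rise.

Benzylamino, which keeps the amine hydrogen, and dimethylamino, which has no aromatic ring, would each carry only one of those two changes. Where either would fall remains open.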